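Working notes: compound 2 to compound 4 in cell assay

This account rests on a few compounds, and the source may have more. Where it says the series, first, only, none or still open, it means among the compounds named here.

Measured compounds and values:
compound 1 `COc1ccc(OC)c(-c2cn(-c3ccc(O)c(C(=O)Nc4cccc(C(F)(F)F)c4)c3)nn2)c1`: 15%
compound 2 `COc1ccc(-c2cn(-c3ccc(O)c(C(=O)O)c3)nn2)cc1`: 9%
compound 3 `COc1ccccc1-c1cn(-c2ccc(O)c(C(=O)O)c2)nn1`: 9%

In a functional assay on CCRF-CEM cells (Homo sapiens) for inhibition, read by MTT assay, with a stated time of 2 days, tested at 10 uM (on this read-out lower numbers stand for less inhibition and higher numbers for more inhibition at the one concentration tested (going by the name of the read-out)), compound 1 gives 15%, compound 2 gives 9% and compound 3 gives 9%. Compound 2 stands level with compound 3 at the digits reported, and together the two are the lowest of the three numbers. The nearest neighbour of compound 2 is compound 3, with no change at the digits reported, within the scatter. The furthest is compound 1, a number a few points higher, also within the scatter. Within the data shown here, no two measured compounds differ in a single place, so no single-point step is available from the measured set.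

Compound 4 `COc1ccc(-c2cn(-c3ccc(O)c(C(=O)OCCCc4ccccc4)c3)nn2)cc1` has not been measured in this assay. It differs from compound 2 by 3-phenylpropyl in place of hydrogen on an oxygen next to a carbonyl group. Cut one bond further out, the same difference reads hydroxy to 3-phenylpropoxy. Nothing measured here bears on this kind of change. All three numbers sit low and close together, so the step is expected to be small, at most a slight rise, and not clearly beyond the scatter. The step expected is a number 5 percentage points higher from compound 2 to compound 4 (within the scatter). Compound 4 is therefore estimated at 14%, with a range from 2% to 32%.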

Compound 4, a percentage reported as inhibition, at one concentration (the size of the read-out at that concentration, not a potency): 5%
Compound 4: middle estimate off by 9 percentage points, on the high side; the range from low to high includes it.
By their numbers in this assay, from the lowest: compounds 4, 2, 3 and 1 (each within the scatter of the next).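

In this assay, among these compounds, 3-phenylpropyl in place of hydrogen on an oxygen next to a carbonyl group gives the first step that can be read at a single place: a number 4 percentage points lower from compound 2 to compound 4 (within the scatter). At this oxygen, then, a group of 9 heavy atoms carrying a six-membered aromatic ring of carbon only leaves the two compounds indistinguishable on this read-out at the one concentration tested, so the hydroxy to 3-phenylpropoxy change opens no clear gain in inhibition. No measurement at hand accounts for this outcome.

Still open, as far as these compounds go, is whether a smaller group such as methyl, or a chain ending in an amine, on the same oxygen would move the read-out beyond the scatter. Also open, from the compounds shown here alone, is whether 3-phenylpropyl would behave the same way on the core of compound 3, where this oxygen also carries hydrogen.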